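Following the sulfonyl group from compound 1 to compound 3

The compounds below may be only part of what the source reports. "The series", "measured", "known", "first", "only" and "open" are said of these compounds alone.

- compound 1 `O=C(O)CC/C=C\C[C@@H]1CN(S(=O)(=O)c2cccc3cnccc23)C[C@H]1c1ccccc1O` gives 0.056 mg/kg
- compound 2 `CC(C)C(=O)N1C[C@@H](C/C=C\CCC(=O)O)[C@@H](c2ccccc2O)C1` gives 0.11 mg/kg

Both compounds were measured in a functional assay on the whole organism (trachea) for inhibition, with Cavia porcellus as the target; on this read-out higher numbers stand for an effect only at larger amounts of compound and lower numbers for an effect already at smaller amounts. The value of compound 1 lies within the usual scatter of the value of compound 2, so neither stands apart from the other. Compound 3 `O=C(O)CC/C=C\C[C@@H]1CN(S(=O)(=O)c2ccc(Cl)cc2)C[C@H]1c1ccccc1O` has not yet been measured. It is derived from compound 1 by a single exchange: 4-chlorophenyl in place of isoquinolin-5-yl on a sulfonyl sulfur. Thus, 4-chlorophenyl stands in place of isoquinolin-5-yl on a sulfonyl sulfur. For the measured compounds named here, no measured step shows what this exchange does, so the expectation rests only on compound 1 at 0.056 mg/kg and is correspondingly wide. No change beyond the scatter is expected in this assay, in either direction. The expected size is a 1.8-fold higher number from compound 1 to compound 3 (0.25 log units; within the scatter). For compound 3 the estimated value is 0.1 mg/kg, with an expected range from 0.03 mg/kg to 0.35 mg/kg.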

Compound 3, dose for 50% inhibition: 0.12 mg/kg
Beside the measured number, compound 3's estimate is 1.2-fold (0.08 log units) below it, within the range that was stated.
By their numbers in this assay, from the lowest: compounds 1, 2 and 3 (each within the scatter of the next, the first and the last beyond it).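

For the compounds shown here, exchanging isoquinolin-5-yl for 4-chlorophenyl on the sulfonyl sulfur gives the first readable step at this position in this assay: a 2.1-fold higher number from compound 1 to compound 3 (0.33 log units; beyond the scatter). The position therefore responds to this exchange, but compound 3 still gives 0.12 mg/kg, so an effect at this level does not depend on keeping the second aromatic ring or the hydrogen-bond acceptor of isoquinolin-5-yl. No available measurement accounts for the step.

From the compounds shown here alone, this single exchange removes the second ring and the ring nitrogen and adds a chlorine all at once, so what each contributes remains open. Going by these compounds, how a plain phenyl or a naphthalen-1-yl group on the same sulfonyl sulfur would compare with compound 1 and compound 3 also remains unknown.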